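Replacing pyridin-4-yl with 5-bromothiophen-2-yl

The compounds below may be only part of what the source reports. "The series", "measured", "known", "first", "only" and "open" are said of these compounds alone.

Compound 1 `COc1cc(NCc2ccc(C)o2)ccc1-c1cnco1` gives 63400 nM
Compound 2 `COc1cc(NCc2ccc(Cl)s2)ccc1-c1cnco1` gives 43200 nM
Compound 3 `COc1cc(NCc2ccncc2)ccc1-c1cnco1` gives 72200 nM

In an ADME assay on Huh-7 cells (Homo sapiens) for cytotoxicity, read by MTT assay, with a stated time of 96 h (on this read-out higher numbers stand for lower toxicity in this test and lower numbers for higher toxicity in this test), compound 3 gives 72200 nM and cannot be told apart from the other two compounds. The comparison shows a 1.1-fold higher number from compound 1 to compound 3 (0.06 log units; within the scatter) and also a 1.7-fold higher number from compound 2 to compound 3 (0.22 log units; within the scatter), so these numbers are best read as one level.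

Compound 4 `COc1cc(NCc2ccc(Br)s2)ccc1-c1cnco1` has not yet been measured. Its difference from compound 3 is 5-bromothiophen-2-yl in place of pyridin-4-yl on a saturated chain carbon bound to a nitrogen on an aromatic ring. In words, this is 5-bromothiophen-2-yl in place of pyridin-4-yl on a saturated chain carbon bound to a nitrogen on an aromatic ring.

The closest guide is the exchange between pyridin-4-yl and 5-chlorothiophen-2-yl, seen as a 1.7-fold higher number from compound 2 to compound 3 (0.22 log units; within the scatter). Read in reverse, it points towards a lower number for compound 4. A second exchange at the same place gives a 1.5-fold lower number from compound 1 to compound 2 (0.17 log units; within the scatter). None of the three measured exchanges goes beyond the scatter, so in this assay a modest step towards a lower number is expected, and none beyond the scatter.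

The expected change is a 1.7-fold lower number from compound 3 to compound 4 (0.23 log units; within the scatter) in this estimate. For compound 4 the estimated value is 43000 nM within an expected range from 22000 nM to 85000 nM.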

Compound 4, half-maximal cytotoxic concentration: 39400 nM
Estimate against measurement, compound 4: 1.1-fold (0.04 log units) above; the measured number falls inside the stated range.
By their numbers in this assay, from the lowest: compounds 4, 2, 1 and 3 (each within the scatter of the next).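

In this assay, the ring can now be held in place while only its halogen changes: bromo in place of chloro on an aromatic carbon gives a 1.1-fold lower number from compound 2 to compound 4 (0.04 log units; within the scatter), which is within the scatter. Exchanges of the whole group also stay within the scatter, with 5-bromothiophen-2-yl in place of pyridin-4-yl giving a 1.8-fold lower number from compound 3 to compound 4 (0.26 log units; within the scatter) and in place of 5-methylfuran-2-yl giving a 1.6-fold lower number from compound 1 to compound 4 (0.21 log units; within the scatter), so all four compounds read as one level, with no step at this position that can be told from repeat-measurement noise. Nothing available gives a reason for this flat picture.

From the compounds shown here alone, all the groups compared here are single aromatic rings, so it remains open whether a primary amine or a carboxylic acid at this place, or a longer chain on the nitrogen in place of the single saturated carbon, would move the number beyond the scatter. These compounds also share one core, so they say nothing about how a change elsewhere in that core would read in this assay.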